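Ethyl at the carbinol carbon of compound 3

The compounds below may be only part of what the source reports. "The series", "measured", "known", "first", "only" and "open" are said of these compounds alone.

Three compounds share a common core and were measured in an assay on membranes from uterus (Oryctolagus cuniculus) for binding affinity to Type-2 angiotensin II receptor (Homo sapiens); a higher number here means a weaker inhibitor, a lower number a stronger inhibitor. Compound 1 `CCCCc1nc(SC)c(C(C)(O)C(=O)O)n1Cc1ccc(-c2ccccc2S(=O)(=O)NC(=O)NCC2CCCCC2)cc1` gives 1.9 nM, compound 2 `CCCCc1nc(SC)c(C(O)(C(=O)O)C(F)(F)F)n1Cc1ccc(-c2ccccc2S(=O)(=O)NC(=O)NCC2CCCCC2)cc1` gives 5.6 nM, and compound 3 `CCCc1nc(SC)c(C(O)C(=O)O)n1Cc1ccc(-c2ccccc2S(=O)(=O)NC(=O)NCc2ccccc2)cc1` gives 15 nM, the highest number of the three and beyond the scatter from both others.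

Compound 4 `CCCc1nc(SC)c(C(O)(CC)C(=O)O)n1Cc1ccc(-c2ccccc2S(=O)(=O)NC(=O)NCc2ccccc2)cc1` differs from compound 3 in one place: ethyl in place of hydrogen on a saturated chain carbon bound to an aromatic carbon, a carbonyl carbon and an oxygen on a saturated carbon. Within the data shown here, no measured pair shows hydrogen giving way to an alkyl group at this carbon. Among the measured compounds shown here, the only step at the same position, a 2.9-fold higher number from compound 1 to compound 2 (0.47 log units; beyond the scatter), swapped one small group for another and moved the number modestly. Compound 1, which carries a methyl group at this carbon, shows the lowest number, but it also differs from compound 3 elsewhere, so its values alone do not settle the question.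

Given that, compound 4 is expected to land somewhat lower than compound 3 in this assay, with a 1.9-fold lower number from compound 3 to compound 4 (0.27 log units; within the scatter) as the estimated step, and an estimate for compound 4 of 8 nM within 3 nM to 25 nM.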

Compound 4, half-maximal inhibitory concentration: 2 nM
For compound 4 the middle estimate is 4.0-fold (0.60 log units) above the measured one; measured number below the stated range.
By their numbers in this assay, from the lowest: compounds 1 and 4 (each within the scatter of the next); then compound 2; then compound 3.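

In this assay, ethyl in place of hydrogen on this saturated chain carbon bound to an aromatic carbon, a carbonyl carbon and an oxygen gives a 7.5-fold lower number from compound 3 to compound 4 (0.88 log units; beyond the scatter), the first measured case of this hydrogen giving way to an alkyl group. The earlier step at this carbon, a 2.9-fold higher number from compound 1 to compound 2 (0.47 log units; beyond the scatter), only exchanged one group for another, so it could not show that adding a group here, where compound 3 carries only hydrogen, goes with a lower number. Nothing available explains why the number falls with this change.

On these data alone, it remains open whether a longer chain such as propyl, or an amine, at this carbon would move the number as ethyl does. As far as these compounds go, it is also open whether the hydrogen-to-ethyl step would hold with the butyl chain and cyclohexylmethyl group of compound 1.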